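Para substituent on the aryl ring: methyl to methoxy

A few compounds are considered here, and "the series" means these few. Any claim that something is new, unique, unknown or untested is made for them only; others in the source may bear on it.

Measured compounds:
- compound 1 `C/C(C(=O)NC1CC1)=C(/C)c1ccccc1` — 100 mg/kg
- compound 2 `C/C(C(=O)NC1CC1)=C(/C)c1ccc(C)cc1` — 110 mg/kg

In a toxicity assay on the whole organism (strain Icem-CET (SPF Caw)) for cytotoxicity, with Mus musculus as the target (a higher number here means that more compound is needed for the effect, a lower number that less compound is needed), compound 1 gives 100 mg/kg and compound 2 gives 110 mg/kg. Within the data shown here, the single step between them, a 1.1-fold higher number from compound 1 to compound 2 (0.04 log units; within the scatter), shows that putting a methyl in place of hydrogen on the aromatic carbon leaves the dose essentially unchanged. On the two numbers available compound 2 gives the higher number, but the gap to compound 1 lies within the scatter, so the two compounds are not separated.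

Compound 3 `COc1ccc(/C(C)=C(\C)C(=O)NC2CC2)cc1` differs from compound 2 in one place: methoxy in place of methyl on an aromatic carbon. Among the measured compounds shown here, the only step that bears on it is the one from compound 1 to compound 2, which was small. For the measured compounds named here, no measured step here tells how exchanging methyl for methoxy at this place affects the whole-organism dose in this assay, so the expectation rests on the small size of that one step. For compound 3 the estimate is 110 mg/kg, with a range of 60 mg/kg to 200 mg/kg, which means an expected step of no change at the digits printed from compound 2 to compound 3 (within the scatter) and thus no change beyond the scatter.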

Compound 3, dose for half-maximal effect: 250 mg/kg
Beside the measured number, compound 3's estimate is 2.3-fold (0.36 log units) below it; the whole stated range lies below it.
By their numbers in this assay, from the lowest: compounds 1 and 2 (each within the scatter of the next); then compound 3.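

In this assay the aromatic carbon para to a large group now proves able to shift the dose beyond the scatter: methoxy in place of methyl gives a 2.3-fold higher number from compound 2 to compound 3 (0.36 log units; beyond the scatter) and methoxy in place of hydrogen gives a 2.5-fold higher number from compound 1 to compound 3 (0.40 log units; beyond the scatter) at the same place. The earlier exchange of hydrogen for methyl did not separate compound 1 from compound 2, so this position is not indifferent to what it carries, and compound 3 needs more compound for the effect than either of the other two. Of the three groups seen here, methoxy alone brings an oxygen and a hydrogen-bond acceptor, but no measurement accompanies this result that would tie the shift to either of these or to anything else about the group.

Open, as far as these compounds go, is whether the shift follows the oxygen itself, which hydroxy or ethoxy at this place would begin to test against ethyl, a group without oxygen. Also open, from the compounds shown here alone, is whether an amine or a carboxylic acid here moves the number the same way, and whether methoxy elsewhere on the aromatic ring does so too.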